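The source may report more compounds than this note shows. Statements on the series, on what has been measured and on what is new or still open speak of the compounds shown alone.

The measured compounds so far:
Compound 1 `C=C1CCC[C@H]2[C@](C)(CC3=C(O)C(=O)C=C(OC)C3=O)[C@@H](C)CC[C@]12C`: 5400 nM
Compound 2 `C=C1CCC[C@H]2[C@](C)(Cc3c(O)c(O)cc4ncoc34)[C@@H](C)CC[C@]12C`: 21000 nM

Both compounds were tested in a functional assay on HT-29 cells (Homo sapiens) for cytotoxicity, read by sulforhodamine B assay, with a stated time of 48 h; on this read-out lower numbers stand for stronger inhibition of growth and higher numbers for weaker inhibition of growth. Compound 1 gives 5400 nM and holds the lowest of the two numbers on record. Compound 2, which gives 21000 nM, stands higher by a gap that lies beyond the usual scatter of this kind of measurement. Within the data shown here, because the two compounds differ in more than one place, no single step between them has been worked out, and nothing more than these two values can be read from the pair.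

Compound 3 `C=C1CCC[C@H]2[C@](C)(CC3=C(O)C(=O)C=C(NCC(=O)O)C3=O)[C@@H](C)CC[C@]12C` has not yet been measured in this assay. It differs from compound 1 in one place only: (carboxymethyl)amino in place of methoxy on a double-bonded ring carbon. Among the measured compounds shown here, no measured pair in this set shows what a change of this kind does, so there is no step to lean on. The step expected here, a 1.5-fold higher number from compound 1 to compound 3 (0.17 log units; within the scatter), is a small one, perhaps in the weakening direction, and it may well fall within the scatter. Compound 3 is accordingly expected to give about 8000 nM, with a range from 2500 nM to 25000 nM.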

Compound 3, concentration for 50% growth inhibition: 6000 nM
The estimate for compound 3 lay 1.3-fold (0.12 log units) above the measured number, and the stated range covers the measured number.
By their numbers in this assay, from the lowest: compounds 1 and 3 (each within the scatter of the next); then compound 2.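

Among these compounds, compound 3 gives the first single-place comparison in this set: in this assay, replacing methoxy with (carboxymethyl)amino on a double-bonded ring carbon gives a 1.1-fold higher number from compound 1 to compound 3 (0.05 log units; within the scatter) and so cannot be told apart from no change. At this position, the core of compound 1 therefore accepts a group with more heavy atoms and with hydrogen-bond donors, which methoxy lacks, without a shift in growth inhibition beyond the scatter. No separate measurement bears on why the two groups read alike, so the result stands here without an explanation.

The compounds shown leave open whether this holds for other groups on the same carbon, such as a plain amine, a longer chain ending in a carboxylic acid, or the methyl ester of the same chain. They also leave open whether the nitrogen or the carboxylic acid of (carboxymethyl)amino contributes anything on its own, and whether the same change would read alike with the ring's hydroxy group replaced by a methoxy group.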